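Replacing a Chloro with Phenyl on a Hydroxamic Acid

The compounds below may be only part of what the source reports. "The series", "measured", "known", "first", "only" and "open" are said of these compounds alone.

For the measured compounds named here, compound 1 `Cn1cc(/C=C/C(=O)c2ccc(Cl)cc2)cc1/C=C/C(=O)NO` stands at the highest of the two numbers measured so far: in an assay on isolated protein for inhibition of histone deacetylase HD1B (Zea mays) (a lower number here means a stronger inhibitor, a higher number a weaker inhibitor), compound 1 gives 29400 nM. Compound 2 `Cn1cc(/C=C/C(=O)c2cccc(Br)c2)cc1/C=C/C(=O)NO` gives 480 nM, and the step of a 61-fold lower number from compound 1 to compound 2 (1.79 log units; beyond the scatter) is the only measured one. It shows that the ring on the carbonyl carbon matters a great deal, but it changes both the halogen and its place, so it bears only loosely on compound 3 `Cn1cc(/C=C/C(=O)c2ccc(-c3ccccc3)cc2)cc1/C=C/C(=O)NO`, which carries phenyl in place of chloro on an aromatic carbon. A lower number in this assay is expected but of uncertain size, so compound 3 is estimated at 8000 nM, between 1500 nM and 40000 nM, a step of a 3.7-fold lower number from compound 1 to compound 3 (0.57 log units; beyond the scatter).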

Compound 3, half-maximal inhibitory concentration: 31800 nM
Compound 3: the middle estimate sits 4.0-fold (0.60 log units) below what was measured; measured number inside the range.
By their numbers in this assay, from the lowest: compound 2; then compounds 1 and 3 (each within the scatter of the next).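

Phenyl in place of chloro on this aromatic carbon gives a 1.1-fold higher number from compound 1 to compound 3 (0.03 log units; within the scatter) in this assay. A single chlorine atom can therefore give way to a whole six-membered aromatic ring of six heavy atoms with no change beyond the scatter, so added size at this place brings no gain here. Nothing available explains this flat result.

As far as these compounds go, whether an amine or a carboxylic acid on this aromatic carbon would shift the number remains open. So does whether the large step of a 61-fold lower number from compound 1 to compound 2 (1.79 log units; beyond the scatter) comes from the bromo group itself or from its place on the ring.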